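Adding a Third Methoxy to the Ketone Ring

The source may hold more compounds than are shown below. What is called first, only, known or untested is meant among the compounds shown, and "the series" means these compounds.

The compounds measured so far, with their read-outs in a functional assay on MDA-MB-231 cells (Homo sapiens) for cytotoxicity, read by sulforhodamine B assay, with a stated time of 48 h, tested at 1 uM; on this read-out lower numbers stand for a stronger effect and higher numbers for a weaker effect at the one concentration tested:
- compound 1, `COc1cc(-c2cc(/C=C/C(=O)c3ccc(N)cc3)[nH]n2)cc(OC)c1OC`: 70%
- compound 2, `COc1ccc(-c2cc(/C=C/C(=O)c3cc(OC)c(OC)c(OC)c3)[nH]n2)cc1OC`: 67%
- compound 3, `COc1ccc(C(=O)/C=C/c2cc(-c3cc(OC)c(OC)c(OC)c3)n[nH]2)cc1OC`: 77%

Compound 3 has the highest number of the three, meaning the weakest effect, but its lead is small: compound 1 lies a few points under it and compound 2 a little further, both within the usual scatter of this assay. On these numbers all three compounds are indistinguishable.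

Compound 4, `COc1cc(C(=O)/C=C/c2cc(-c3cc(OC)c(OC)c(OC)c3)n[nH]2)cc(OC)c1OC`, is the next compound. It differs from compound 3 by methoxy in place of hydrogen on an aromatic carbon, so that the ring attached to the carbonyl carbon now carries three methoxy groups instead of two.

Among the compounds with values here, only one measured step touches this ring. Replacing the 4-aminophenyl of compound 1 by the 3,4-dimethoxyphenyl of compound 3 gave a number 7 percentage points higher from compound 1 to compound 3 (within the scatter), a change well inside the scatter. Within the data shown here, compound 2 also carries a trimethoxyphenyl on the carbonyl, and its value of 67% sits close to that of compound 3, though two groups are exchanged between them, so no single step can be drawn. A further methoxy on this ring is therefore expected to move this assay little, if at all: the expected step is a number 3 percentage points lower from compound 3 to compound 4 (within the scatter), none beyond the scatter.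

Compound 4 is estimated at 74%, in the range 60% to 88%.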

Compound 4, a percentage reported as activity, at one concentration (the size of the read-out at that concentration, not a potency): 73%
Compound 4: middle estimate off by 1 percentage points, on the high side; the measured number falls inside the stated range.
By their numbers in this assay, from the lowest: compounds 2, 1, 4 and 3 (each within the scatter of the next).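

In this assay, within the data shown here, adding a methoxy in place of hydrogen on the ring attached to the carbonyl carbon gives a number 4 percentage points lower from compound 3 to compound 4 (within the scatter), the first step that changes only the methoxy count on this ring, and the change cannot be told from the scatter. The same exchange on the other aromatic ring gives a number 6 percentage points higher from compound 2 to compound 4 (within the scatter), also within the scatter, so in these two pairs the extra methoxy has no measurable effect on either ring at the one concentration tested. Nothing available here bears on why these steps are so small, and no measurement beyond this read-out accompanies them.

Among these compounds, it remains open whether a different group on this aromatic carbon, such as a hydroxyl, a carboxylic acid or a longer alkoxy chain, would move the number beyond the scatter, since methoxy and hydrogen are the only two groups compared here. Going by these compounds, it also remains open whether these compounds, which cannot be separated at one concentration, would show a stronger or weaker effect relative to one another at other concentrations.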